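Swapping the aryl group on a sulfonamide nitrogen

The source may report more compounds than this note shows. Statements on the series, on what has been measured and on what is new or still open speak of the compounds shown alone.

Measured compounds:
Compound 1 `O=C1NCCN1c1ccc(S(=O)(=O)Nc2ccc(C3CCCCC3)cc2)cc1`: in a functional assay on HT-29 cells (Homo sapiens) for antiproliferative activity, read by sulforhodamine B assay, with a stated time of 48 h (a higher number here means a weaker inhibitor, a lower number a stronger inhibitor), compound 1 gives only a limit, > 1000 nM.
Compound 2 `O=C1NCCN1c1ccc(S(=O)(=O)Nc2ccc(F)cc2)cc1`: in this assay compound 2 gives 370 nM.
Compound 3 `O=C1NCCN1c1ccc(S(=O)(=O)Nc2ccc(OC(F)F)cc2)cc1`: in this assay compound 3 gives 650 nM.

All three share one core and differ only in the group on the aromatic ring attached to the sulfonamide nitrogen. Compound 2 has the lowest of the two numbers, with compound 3 nearest: a 1.8-fold higher number from compound 2 to compound 3 (0.24 log units; within the scatter). Compound 1 is reported only as a limit, so the step of an at least 2.7-fold lower number from compound 1 to compound 2 (0.43 log units; beyond the scatter) is open-ended because compound 1 sits at the limit of > 1000 nM in this assay, at which 1 of the 3 values shown sits. The same holds for an at least 1.5-fold lower number from compound 1 to compound 3 (0.18 log units; that floor lies within the scatter).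

Compound 4 `Cc1ccc(C)c(NS(=O)(=O)c2ccc(N3CCNC3=O)cc2)c1` has not yet been measured. Relative to compound 2 the change is 2,5-dimethylphenyl in place of 4-fluorophenyl on a sulfonamide nitrogen. Among the measured compounds shown here, two steps bear on it: the move from cyclohexyl to fluoro gave a lower number, at least modestly, while the move from fluoro to difluoromethoxy stayed within the scatter. A bulkier carbon group returning to this position therefore suggests a higher number, probably modest rather than large. Compound 4 is expected to give 800 nM, with a range of 300 nM to 2500 nM. The estimated step is a 2.2-fold higher number from compound 2 to compound 4 (0.33 log units; beyond the scatter).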

Compound 4, half-maximal inhibitory concentration: 46 nM
Compound 4: middle estimate off by 17-fold (1.24 log units), on the high side; the whole stated range lies above it.
By their numbers in this assay, from the lowest: compound 4; then compounds 2 and 3 (each within the scatter of the next). At a limit, above all of these: compound 1.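

In this assay, the step to 2,5-dimethylphenyl in place of 4-fluorophenyl on a sulfonamide nitrogen is an 8.0-fold lower number from compound 2 to compound 4 (0.91 log units; beyond the scatter), which gives compound 4 the lowest number of the series and shows that the result at this position is sensitive to the choice of aryl group. Compounds 2 and 3 each carry one non-carbon-only group on the ring, whereas compound 4 carries two methyl groups, so a ring bearing only carbon substituents can go with a low number here. The idea that carbon groups at this position raise the number, which compound 1 alone might have suggested, is therefore not general, and compound 4 goes against it.

The compounds shown do not separate the two methyl groups, so it remains open what a single methyl group would give, or how an amine, a carboxylic acid or a longer chain on the same ring would compare. The size of the gap between compound 1 and compound 4 also cannot be read, because compound 1 is reported only as a limit: the limit of > 1000 nM in this assay, at which 1 of the 4 values shown sits.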